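The source may report more compounds than this note shows. Statements on the series, on what has been measured and on what is new or still open speak of the compounds shown alone.

In a functional assay on A549 cells (Homo sapiens) for inhibition, read by sulforhodamine B assay, with a stated time of 72 h (a lower number here means a stronger inhibitor of growth, a higher number a weaker inhibitor of growth), compound 1 `CNC(=O)/C=C/c1ccncc1-c1ccc2cc[nH]c2c1` gives 7840 nM. Compound 2 `CCOC(=O)/C=C/c1ccncc1-c1ccc2[nH]ccc2c1` gives 7440 nM, a number within the scatter of that of compound 1. Compound 3 `O=C(O)/C=C/c1ccncc1-c1ccc2ccccc2c1` reads > 10000 nM, which is a limit of the assay and not a number.

Compound 4 `O=C(/C=C/c1ccncc1-c1ccc2cc[nH]c2c1)N1CCOCC1` keeps the core of compound 1 and carries morpholin-4-yl in place of methylamino on a carbonyl carbon. No measured pair among these compounds shows a change of this kind, so the expectation in this assay is of no step beyond the scatter, in either direction. The estimated 1.0-fold higher number from compound 1 to compound 4 (0.01 log units; within the scatter) is therefore small. For compound 4 the expected value is 8000 nM, with an estimated range of 3000 nM to 15000 nM.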

Compound 4, concentration for 50% growth inhibition: > 10000 nM
Compound 4 was reported as a limit; the forecaster's own chance of this, stated with the estimate: 35%; at least 1.2-fold (0.09 log units) between middle value and limit.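

In this assay, for the compounds shown here, the swap on this carbonyl carbon gives the first step that can be read at this place: an at least 1.2-fold higher number from compound 1 to compound 4 (0.10 log units; that floor lies within the scatter). Compound 4 stands at > 10000 nM, which is a limit of the assay and not a number. Whether the step goes beyond the scatter therefore stays unsettled, because the reading stops at that limit: the limit of > 10000 nM in this assay, at which 2 of the 4 values shown sit.

The compounds shown leave open how dimethylamino or piperidin-1-yl would read on this carbonyl carbon. They also leave open whether a longer chain on the amide nitrogen would change the number.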